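The source may hold more compounds than are shown below. What is called first, only, known or untested is meant among the compounds shown, and "the series" means these compounds.

Measured compounds:
compound 1, `N#Cc1ccc(Nc2nccc(Nc3c(Br)cc(F)cc3Br)n2)cc1`, 0.94;
compound 2, `Cc1cc(C#N)cc(C)c1Oc1nc(Nc2ccc(C#N)cc2)ncc1Br`, 1.82;
compound 3, `Cc1cc(C)c(Nc2nc(Nc3ccc(C#N)cc3)ncc2Cl)c(C)c1`, 1.8.

Three compounds have been characterised in a physicochemical assay for lipophilicity; on this read-out higher numbers stand for higher lipophilicity and lower numbers for lower lipophilicity. In this assay compound 1 gives 0.94, compound 2 gives 1.82 and compound 3 gives 1.8. The number for compound 2 lies within the usual scatter of the number for compound 3, so no order can be read between those two; against compound 1 the gap is beyond the scatter, and compound 1 sits lower.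

The unmeasured compound 4, `Cc1cc(C#N)cc(C)c1Oc1nc(Nc2ccc(C#N)cc2)ncc1[N+](=O)[O-]`, is compared with compound 2. The structural change is nitro in place of bromo on an aromatic carbon, in short a nitro in place of bromo on an aromatic carbon, two atoms from the ring nitrogen. For the measured compounds named here, no measured pair with this same change exists among the three compounds, so the size of the step has to be an expectation rather than a reading from data. The author expects the step from compound 2 to compound 4 in this assay to be a downward one, a number 0.92 log units lower from compound 2 to compound 4 (beyond the scatter), beyond the scatter. Compound 4 is therefore estimated at 0.9, with a range from 0.4 to 1.4.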

Compound 4, partition coefficient: -0.98
The estimate for compound 4 lay 1.88 log units above the measured number; the measured number lies below the stated range.
By their numbers in this assay, from the lowest: compound 4; then compound 1; then compounds 3 and 2 (each within the scatter of the next).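

In this assay, nitro in place of bromo on an aromatic carbon gives a number 2.80 log units lower from compound 2 to compound 4 (beyond the scatter), a large step at this position, para to a (4-cyanophenyl)amino group. For the compounds shown here, the earlier compounds offered no pair differing in one place, so this is the first direct reading of a change here, and it shows that this one substituent can move the number far beyond the scatter. Nothing available explains why the step is this large.

The compounds shown leave open where an amine or a methoxy group at this same position would fall relative to bromo and nitro. This one pair also cannot show whether the same exchange would give a step of similar size on the core of compound 3 or compound 1.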